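Ethyl for 3-Methylphenyl on the Ring Nitrogen

A few compounds are considered here, and "the series" means these few. Any claim that something is new, unique, unknown or untested is made for them only; others in the source may bear on it.

Three compounds share one core and differ only in the group on an amide-type nitrogen in a ring. Going by the values given here, in a functional assay on HOS-TE85 cells (Homo sapiens) for inhibition, read by CCK-8 assay, with a stated time of 72 h (a lower number here means a stronger inhibitor, a higher number a weaker inhibitor), compound 3 `Cc1cccc(N2C(=O)CSC2c2cccc(C(=O)NCCCCc3ccccc3)c2)c1`, with 3-methylphenyl there, gives 93.2 nM, the only exact number so far. Compound 1 `O=C(NCCCCc1ccccc1)c1cccc(C2SCC(=O)N2c2cnccn2)c1`, with pyrazin-2-yl, gives > 1000 nM, which is a limit of the assay. Compound 2 `COc1ccc(OC)c(N2C(=O)CSC2c2cccc(C(=O)NCCCCc3ccccc3)c2)c1`, with 2,5-dimethoxyphenyl, gives > 1000 nM, also a limit. The two measured steps to 3-methylphenyl are both large and beyond the scatter: an at least 10-fold lower number from compound 1 to compound 3 (1.03 log units; beyond the scatter) and an at least 10-fold lower number from compound 2 to compound 3 (1.03 log units; beyond the scatter).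

Compound 4 `CCN1C(=O)CSC1c1cccc(C(=O)NCCCCc2ccccc2)c1` changes this same place, with ethyl in place of 3-methylphenyl on an amide-type nitrogen in a ring. No alkyl group has been measured here, so the guide is indirect. The steps of an at least 10-fold lower number from compound 1 to compound 3 (1.03 log units; beyond the scatter) and an at least 10-fold lower number from compound 2 to compound 3 (1.03 log units; beyond the scatter) show that this group can shift the number strongly, and only 3-methylphenyl has given an exact value. A large step towards weaker inhibition is therefore expected, and the result may also stop at a limit. The expected change is a 9.7-fold higher number from compound 3 to compound 4 (0.98 log units; beyond the scatter). Compound 4 is estimated at 900 nM, with an expected range of 200 nM to 4000 nM.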

Compound 4, half-maximal inhibitory concentration: > 1000 nM
Compound 4: only a limit was reported; the forecaster's own chance of this, stated with the estimate: 45%; at least 1.1-fold (0.04 log units) between middle value and limit.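

Ethyl is the only alkyl group shown on this nitrogen, and in this assay it gives an at least 10-fold higher number from compound 3 to compound 4 (1.03 log units; beyond the scatter), so the activity of compound 3 does not survive this swap of an aromatic ring for a short chain without a ring. Compound 4 gives > 1000 nM, which is a limit of the assay and not a number. Of the four groups, only 3-methylphenyl gives an exact value, and the steps among compounds 1, 2 and 4 cannot be read: the limit of > 1000 nM in this assay, at which 3 of the 4 values shown sit.

The compounds shown leave open whether plain phenyl, without the methyl group, would match compound 3. They also leave open how a longer chain such as butyl, or a benzyl group, would behave on this nitrogen.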